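The source may report more compounds than this note shows. Statements on the series, on what has been measured and on what is new or still open speak of the compounds shown alone.

Working notes on the acylurea–hydrazone series

Compound 1 `CN(C(=O)NC(=O)c1cccc(C(F)(F)F)c1)c1nc(C(F)(F)F)c(C(=O)N/N=C/c2cccc(C(F)(F)F)c2)s1` gives 5.79 ug/mL in a functional assay on HepG2 cells (Homo sapiens) for inhibition, read by MTT assay, with a stated time of 72 h; on this read-out higher numbers stand for weaker inhibition and lower numbers for stronger inhibition. On the numbers in hand it carries the lowest figure of the three measured compounds, though neither neighbour is separated from it by more than the usual scatter: compound 3 `CN(C(=O)NC(=O)c1ccc(Cl)c(Cl)c1)c1nc(C(F)(F)F)c(C(=O)N/N=C/c2cccc([N+](=O)[O-])c2)s1` gives 7.98 ug/mL in this assay, and compound 2 `CN(C(=O)NC(=O)c1cccc(C(F)(F)F)c1)c1nc(C(F)(F)F)c(C(=O)N/N=C/c2ccccc2C(F)(F)F)s1` gives 10.4 ug/mL. Going by the values given here, the only single-point step measured so far, a 1.8-fold higher number from compound 1 to compound 2 (0.25 log units; within the scatter), sits at the hydrazone end of the molecule and stays within the scatter.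

Compound 4 `CN(C(=O)NC(=O)c1ccc(Cl)cc1Cl)c1nc(C(F)(F)F)c(C(=O)N/N=C/c2cccc(C(F)(F)F)c2)s1` differs from compound 1 at the other end of the core: 2,4-dichlorophenyl in place of 3-(trifluoromethyl)phenyl on a carbonyl carbon. Among the compounds with values here, no measured pair isolates this change. Compound 3 also carries a dichlorophenyl on the carbonyl carbon, but it differs from compound 1 in two places at once, so its value and that of compound 1 can only be noted side by side; read together they give no sign of a large shift. With the one measured step lying elsewhere and within the scatter, and no listed step reporting a move beyond it, the working expectation is no change beyond the scatter in this assay, which is a step of a 1.1-fold higher number from compound 1 to compound 4 (0.05 log units; within the scatter). Compound 4 is therefore estimated at 6.5 ug/mL, within a range of 3.2 ug/mL to 13 ug/mL.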

Compound 4, half-maximal inhibitory concentration: 11.2 ug/mL
Compound 4: the middle estimate sits 1.7-fold (0.24 log units) below what was measured; the measured number falls inside the stated range.
By their numbers in this assay, from the lowest: compounds 1, 3, 2 and 4 (each within the scatter of the next).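

Going by these compounds alone, the first single-point step at this position, with 2,4-dichlorophenyl in place of 3-(trifluoromethyl)phenyl on a carbonyl carbon, gives in this assay a 1.9-fold higher number from compound 1 to compound 4 (0.29 log units; within the scatter) and so does not resolve the two aryl groups. With a 1.8-fold higher number from compound 1 to compound 2 (0.25 log units; within the scatter) at the hydrazone end, each end of the molecule now has one single-point step, and neither step lies beyond the scatter, a statement that holds only for these compounds and these two changes. Nothing available here bears on the origin of the step at the carbonyl carbon.

Still open, on these data alone, is whether anything other than a halogen- or trifluoromethyl-substituted phenyl on this carbonyl carbon, such as a phenyl carrying an amine or a carboxylic acid, or a saturated cyclohexyl ring or a longer alkyl chain in place of the aryl group, would move the number beyond the scatter in this assay on the core of compound 1. Also open is whether the dichlorophenyl group of compound 3 behaves on its own as the 2,4-dichlorophenyl group does, since compound 3 has no single-point partner among these compounds.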